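Methyl on the aromatic ring: carrying a step across two cores

The compounds below may be only part of what the source reports. "The series", "measured", "known", "first", "only" and "open" are said of these compounds alone.

The measured compounds and their values:
Compound 1, `Cn1c2c(c3ccccc3c1=O)CCOc1ccccc1-2`, gives 37600 nM.
Compound 2, `Cc1ccc2c3c(n(C)c(=O)c2c1)-c1ccccc1OCC3`, gives 14100 nM.
Compound 3, `COCOc1ccccc1-c1cc2ccccc2c(=O)[nH]1`, gives 620 nM.

All three were tested in a functional assay on HL-60 cells (Homo sapiens) for cytotoxicity, read by sulforhodamine B assay; a lower number here means a stronger inhibitor, a higher number a weaker inhibitor. Compound 1 and compound 2 share one core and differ in one place, (methyl in place of hydrogen on an aromatic carbon), and this change made a step of a 2.7-fold lower number from compound 1 to compound 2 (0.43 log units; beyond the scatter). Compound 3 is built on a different core; the difference between the two cores is not broken down here. Its own number stands well apart: it is the lowest of the three, and its distance from compound 2 and from compound 1 lies beyond the scatter in each case.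

Compound 4, `COCOc1ccccc1-c1cc2cc(C)ccc2c(=O)[nH]1`, has not yet been measured. It differs from compound 3 by methyl in place of hydrogen on an aromatic carbon. This is the same kind of change as that from compound 1 to compound 2, though not the same: in compound 2 the methyl sits on a ring that is part of a fused or bridged system of four rings, in compound 4 on a ring that is part of a fused or bridged system of two rings.

In this assay a step of a 2.1-fold lower number from compound 3 to compound 4 (0.32 log units; beyond the scatter) is expected, resting on the step of a 2.7-fold lower number from compound 1 to compound 2 (0.43 log units; beyond the scatter) seen for the same kind of change on the other core, and tempered because that step was measured in compound 1 and compound 2 alone. Compound 4 is therefore estimated at 300 nM, within the range 120 nM to 800 nM.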

Compound 4, half-maximal inhibitory concentration: 160 nM
For compound 4 the middle estimate is 1.9-fold (0.27 log units) above the measured one, and the stated range covers the measured number.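

In this assay, methyl in place of hydrogen on an aromatic carbon gave a 3.9-fold lower number from compound 3 to compound 4 (0.59 log units; beyond the scatter), so the number fell on this core as it had on the core of compound 1. Set side by side, the two steps run in the same direction and cannot be told apart in size: the same change on two cores in this assay, a 2.7-fold lower number (0.43 log units; beyond the scatter) from compound 1 to compound 2 and a 3.9-fold lower number (0.59 log units; beyond the scatter) from compound 3 to compound 4, 1.5-fold (0.16 log units) apart, within the scatter of two such steps This shows that, for these two pairs in this one assay, the step carried from one core to the other, even though the methyl sits on a ring in a fused or bridged system of four rings in compound 2 and of two rings in compound 4; it does not show that the step would carry to a third core, and it gives no reason for the fall in either pair.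

The compounds shown leave open whether a group other than methyl on the same aromatic carbon, such as an ethyl, a methoxy or a chlorine, would bring a step of similar size on both cores. They also leave open whether methyl on another carbon of the ring would behave alike, and how the step would stand on compound 3 with a free hydroxyl in place of its methoxymethoxy group.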